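Methylating the Ring Amide Nitrogen: A Second Look

The compounds below may be only part of what the source reports. "The series", "measured", "known", "first", "only" and "open" are said of these compounds alone.

Compound 1 `COc1cc2c(cc1C)NC(=O)/C2=C/c1c(Cl)n(C)c2cc(C)c(OC)cc12` carries a hydrogen on the amide-type nitrogen in its five-membered ring, and in a functional assay on cells (Cancer cell lines, Homo sapiens) for inhibition, with a stated time of 48 h (on this read-out lower numbers stand for stronger inhibition of growth and higher numbers for weaker inhibition of growth), compound 1 gives 41700 nM. Compound 2 `COc1cc2c(cc1C)N(C)C(=O)/C2=C/c1c(Cl)n(C)c2cc(C)c(OC)cc12` differs from it by one change only, (methyl in place of hydrogen on an amide-type nitrogen in a ring), and in this assay compound 2 gives 15900 nM. That single change produced a 2.6-fold lower number from compound 1 to compound 2 (0.42 log units; beyond the scatter).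

Compound 3 `CN(C)c1ccc2[nH]c(Cl)c(/C=C3/C(=O)Nc4ccc(O)cc43)c2c1` is built on a different core; the difference between the two cores is not broken down here. In this assay, among the measured compounds shown here, compound 3 gives 5130 nM, the lowest of the three numbers measured so far, with its steps to compound 2 and to compound 1 both beyond the usual scatter.

Compound 4 `CN(C)c1ccc2[nH]c(Cl)c(/C=C3/C(=O)N(C)c4ccc(O)cc43)c2c1` has not yet been measured. It differs from compound 3 by methyl in place of hydrogen on an amide-type nitrogen in a ring, the same change that separates compound 1 from compound 2. Because that change gave a 2.6-fold lower number from compound 1 to compound 2 (0.42 log units; beyond the scatter), a step of similar size is expected here, so that compound 4 is estimated to sit at a 2.1-fold lower number from compound 3 to compound 4 (0.33 log units; beyond the scatter). For compound 4 the expected value in this assay is 2400 nM, most likely between 1000 nM and 6500 nM.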

Compound 4, concentration for 50% growth inhibition: 4370 nM
Estimate against measurement, compound 4: 1.8-fold (0.26 log units) below; the range from low to high includes it.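

On the core of compound 3, methyl in place of hydrogen on the ring amide nitrogen gives a 1.2-fold lower number from compound 3 to compound 4 (0.07 log units; within the scatter) in this assay and so cannot be told apart from the ordinary variation between repeat measurements. The step seen on the core of compound 1 was larger on paper, yet the two steps cannot be called different: the same change on two cores in this assay, a 2.6-fold lower number (0.42 log units; beyond the scatter) from compound 1 to compound 2 and a 1.2-fold lower number (0.07 log units; within the scatter) from compound 3 to compound 4, 2.2-fold (0.35 log units) apart, within the scatter of two such steps. This shows that the result on the second core does not conflict with the first, but it does not show that the clear drop on the first core repeats on the second, and two pairs say nothing about any other core.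

The compounds shown carry only hydrogen or methyl on this nitrogen, which leaves open how a longer chain such as ethyl, or a chain ending in an amine or a carboxylic acid, would behave there. Also open, going by these compounds, is whether repeat measurements of such pairs would narrow the uncertainty around these small steps.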